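Sulfonyl aryl variation in the nicotinamide series

The compounds below may be only part of what the source reports. "The series", "measured", "known", "first", "only" and "open" are said of these compounds alone.

Compound 1 `Cc1cccc(S(=O)(=O)NCc2ccc(CNC(=O)c3cccnc3)cc2)c1` and compound 2 `O=C(NCc1ccc(CNS(=O)(=O)c2ccc([N+](=O)[O-])cc2)cc1)c1cccnc1` share the same core and differ only in the aryl group on the sulfonyl sulfur. Going by the values given here, in an assay on MDA-MB-231 cells for displacement of a labelled ligand from C-X-C chemokine receptor type 4 (Homo sapiens), read by fluorescence and microscopy, with stated times of 10 min and 30 min (on this read-out higher numbers stand for an effect only at larger amounts of compound and lower numbers for an effect already at smaller amounts), compound 1 gives 10 nM, and compound 2 gives 100 nM; that is the higher of the two numbers measured so far, the step of a 10-fold higher number from compound 1 to compound 2 (1.00 log units; beyond the scatter) lying beyond the scatter. Compound 3 `O=C(NCc1ccc(CNS(=O)(=O)c2ccc(Cl)cc2)cc1)c1cccnc1` keeps the core of compound 2 and differs from it at one place: chloro in place of nitro on an aromatic carbon. Among the compounds with values here, no measured step isolates this exchange. Within the data shown here, the single step on record, a 10-fold higher number from compound 1 to compound 2 (1.00 log units; beyond the scatter), changes both the group and where it sits on the ring, so it cannot be read as a guide to chloro against nitro; it shows only that the 4-nitrophenyl variant is the weaker of the two measured. With nothing directly bearing on the change, a modest lowering is expected for compound 3, a 2.5-fold lower number from compound 2 to compound 3 (0.40 log units; beyond the scatter), with a wide range that includes no change beyond the scatter. Compound 3 is estimated at 40 nM, between 12 nM and 130 nM.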

Compound 3, effective concentration (reported as EC, without a stated level of effect): 1000 nM
The estimate for compound 3 lay 25-fold (1.40 log units) below the measured number, outside the stated range (above it).
By their numbers in this assay, from the lowest: compound 1; then compound 2; then compound 3.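

Replacing nitro by chloro on the aromatic carbon para to a large group is not a neutral exchange: in this assay it gives a 10-fold higher number from compound 2 to compound 3 (1.00 log units; beyond the scatter), so the group held at this place on the sulfonyl aryl ring clearly shapes the read-out, and the direction of the step runs from nitro, the larger group with hydrogen-bond acceptors, to chloro, which has none. With a 100-fold higher number from compound 1 to compound 3 (2.00 log units; beyond the scatter), the 4-chlorophenyl variant also widens the span across the sulfonyl aryl groups on the shared core, and 3-methylphenyl remains the variant with the lowest number among the three, although this step, like the one to the 4-nitrophenyl variant, changes the group and its place together. No available data explain why chloro gives a higher number than nitro here.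

The three compounds do not separate the identity of the group from its place on the ring, which a 4-methylphenyl or 3-chlorophenyl variant on the same core would address. Also open, going by these compounds, is how a methoxy group, an amine or a carboxylic acid at the nitro-bearing carbon would fall relative to nitro and chloro.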